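The source may report more compounds than this note shows. Statements on the series, on what has been measured and on what is new or still open speak of the compounds shown alone.

Measured compounds:
- Compound 1 `Cc1ccccc1-c1nnc(SCCn2c([N+](=O)[O-])cnc2C)o1`: 15800 nM
- Compound 2 `Cc1ccc(-c2nnc(SCCn3c([N+](=O)[O-])cnc3C)o2)cc1`: 15500 nM
- Compound 3 `Cc1ccc(-c2nnc(SCCn3c([N+](=O)[O-])cnc3C)o2)c(O)c1`: 23500 nM

In a functional assay on MCF7 cells (Homo sapiens) for cytotoxicity, read by MTT assay, with a stated time of 48 h (a lower number here means a stronger inhibitor, a higher number a weaker inhibitor), compound 2 gives 15500 nM, the lowest of the three numbers, but its distances to compound 1 and to compound 3 both lie within the scatter, so the three compounds cannot be separated on this evidence. The steps among them are all small: a 1.0-fold lower number from compound 1 to compound 2 (0.01 log units; within the scatter), a 1.5-fold higher number from compound 1 to compound 3 (0.17 log units; within the scatter) and a 1.5-fold higher number from compound 2 to compound 3 (0.18 log units; within the scatter). Each of these steps moves or adds a small group on the phenyl ring that hangs from the shared core; none of them exchanges that ring for another kind of ring.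

Compound 4 `Cc1ncc([N+](=O)[O-])n1CCSc1nnc(-c2ccnc(Cl)c2)o1` is the next member of the series. It differs from compound 2 by 2-chloropyridin-4-yl in place of 4-methylphenyl on an aromatic carbon. Going by the values given here, no measured step bears directly on this kind of exchange; the three steps seen only show that changes on the aromatic ring at this position left the number within the scatter. Among the compounds with values here, with that as the sole guide, compound 4 is expected to sit close to compound 2, with a 1.0-fold lower number from compound 2 to compound 4 (0.01 log units; within the scatter) as the expected step, and the uncertainty is wider than for the measured steps. The estimate for compound 4 in this assay is 15000 nM, with a range from 6000 nM to 40000 nM.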

Compound 4, half-maximal inhibitory concentration: 40500 nM
The estimate for compound 4 lay 2.7-fold (0.43 log units) below the measured number, and the stated range ends below it.
By their numbers in this assay, from the lowest: compounds 2, 1, 3 and 4 (each within the scatter of the next, the first and the last beyond it).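

In this assay, going by these compounds alone, replacing the carbon-only aromatic ring on this carbon of the five-membered ring with 2-chloropyridin-4-yl gives the first steps that lie beyond the scatter (a 2.6-fold higher number from compound 2 to compound 4 (0.42 log units; beyond the scatter)) and (a 2.6-fold higher number from compound 1 to compound 4 (0.41 log units; beyond the scatter)), both modest in size, whereas the changes among the substituted phenyl groups all stayed within it. The separation is only partial: the step from the hydroxy-bearing compound (a 1.7-fold higher number from compound 3 to compound 4 (0.24 log units; within the scatter)) lies within the scatter, so compound 4 stands apart from compound 1 and compound 2 but not from compound 3. This position therefore responds to an exchange of the aromatic ring itself, at least for this group, although nothing measured here accounts for that response.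

Since the ring nitrogen and the chlorine enter together, the compounds shown leave open which of the two goes with the higher number, a question that pyridin-4-yl without the chlorine and 4-chlorophenyl would separate. They also leave open how this position would respond to a ring bearing an amine or a carboxylic acid in place of the chlorine.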